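Hydroxy in Place of Chloro: Expecting Compound 4

The source may report more compounds than this note shows. Statements on the series, on what has been measured and on what is new or still open speak of the compounds shown alone.

Compound 2 `COc1cc(Oc2cccc(Nc3ccccc3)c2)cc(OC)c1CNCc1ccc(Cl)cc1` stands with the highest number of the three measured compounds in a functional assay on HCT-15 cells (Homo sapiens) for inhibition, read by MTT assay, with a stated time of 72 h (on this read-out higher numbers stand for weaker inhibition and lower numbers for stronger inhibition), where compound 2 gives 4850 nM. Compound 3 `COc1ccc([C@@H](C)NCc2c(OC)cc(Oc3cccc(Nc4ccccc4)c3)c(OC)c2OC)cc1` gives 4690 nM, a gap within the scatter, while compound 1 `COc1ccc(CCCNCc2c(OC)cc(Oc3ccc(Nc4ccccc4)cc3)cc2OC)cc1` gives 2180 nM, a gap beyond it. Compound 4 `COc1cc(Oc2cccc(Nc3ccccc3)c2)cc(OC)c1CNCc1ccc(O)cc1` is not yet measured; it differs from compound 2 in one place: hydroxy in place of chloro on an aromatic carbon. Among the compounds with values here, no pair of measured compounds shows this particular change, so there is no precedent in this assay to lean on. The author expects a step of a 1.0-fold higher number from compound 2 to compound 4 (0.01 log units; within the scatter) that stays within the scatter, in no settled direction. Compound 4 is therefore estimated at 5000 nM, with a range from 2000 nM to 12000 nM.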

Compound 4, half-maximal inhibitory concentration: 3430 nM
For compound 4 the middle estimate is 1.5-fold (0.16 log units) above the measured one; low and high end bracket the measured number.
By their numbers in this assay, from the lowest: compounds 1, 4, 3 and 2 (each within the scatter of the next, the first and the last beyond it).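

In this assay, replacing 4-chlorobenzyl with 4-hydroxybenzyl gives a 1.4-fold lower number from compound 2 to compound 4 (0.15 log units; within the scatter). This position, para to a large group, therefore accepts the hydroxy in place of the chloro, and the hydrogen-bond donor and acceptor that enter with it do not carry the number beyond the scatter. Nothing available bears on why the two groups read alike.

From the compounds shown here alone, whether an amine or a carboxylic acid at this position would also stay within the scatter remains open. So does whether the same exchange would read alike on another core.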